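Swapping Ethyl for Methylsulfanyl on the Shared Core

This account rests on a few compounds, and the source may have more. Where it says the series, first, only, none or still open, it means among the compounds named here.

In a functional assay on V79 cells (Cricetulus griseus) for cytotoxicity, read by colony formation (on this read-out higher numbers stand for weaker inhibition and lower numbers for stronger inhibition), compound 3 `CCc1c(F)c(N2CCC(N)C2)cc2c1c(=O)c(C(=O)O)cn2C1CC1` gives 46 ug/mL, the second highest of three numbers. Compound 1 `CC1(CN)CCN(c2c(F)cc3c(=O)c(C(=O)O)cn(C4CC4)c3c2C(F)(F)F)C1` stands higher at 110 ug/mL, and compound 2 `Cc1c(F)c(N2CCC(N)C2)cc2c1c(=O)c(C(=O)O)cn2C1CC1` stands lower at 14 ug/mL.

Compound 4 `CSc1c(F)c(N2CCC(N)C2)cc2c1c(=O)c(C(=O)O)cn2C1CC1` has not yet been measured. It carries methylsulfanyl in place of ethyl on an aromatic carbon, ortho to a fluoro group and ortho to a fused ring: methylsulfanyl in place of ethyl on an aromatic carbon.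

Among the measured compounds shown here, only one measured step bears on this change: a 3.3-fold higher number from compound 2 to compound 3 (0.52 log units; beyond the scatter). That step is methyl in place of hydrogen on a saturated chain carbon bound to an aromatic carbon, so it shows that a small change in this group can move the number beyond the scatter. For the measured compounds named here, no measured step replaces ethyl with methylsulfanyl, so the direction remains uncertain. A small step towards a lower number in this assay is expected, within the scatter. The estimated change is a 1.5-fold lower number from compound 3 to compound 4 (0.19 log units; within the scatter). For compound 4 the estimated value is 30 ug/mL, with an expected range of 11 ug/mL to 85 ug/mL.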

Compound 4, half-maximal inhibitory concentration: 92 ug/mL
Compound 4: the middle estimate sits 3.1-fold (0.49 log units) below what was measured; the measured number lies above the stated range.
By their numbers in this assay, from the lowest: compound 2; then compounds 3, 4 and 1 (each within the scatter of the next, the first and the last beyond it).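

In this assay the swap of ethyl for methylsulfanyl comes to a 2.0-fold higher number from compound 3 to compound 4 (0.30 log units; within the scatter), so on this aromatic carbon, ortho to a fluoro group and ortho to a fused ring, these two groups cannot be told apart. Set against methyl, the same group gives a 6.6-fold higher number from compound 2 to compound 4 (0.82 log units; beyond the scatter), a wider step than the one from methyl to ethyl, and of the three groups at this carbon only the methyl of compound 2 stands apart from the other two on this read-out. Nothing at hand accounts for this result.

The compounds shown leave open whether a longer chain such as propyl, or a methoxy group or an amine, on this carbon would group with ethyl and methylsulfanyl or with methyl. They also leave open whether the same grouping would hold with another ring in place of the 3-aminopyrrolidin-1-yl group.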